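The source may report more compounds than this note shows. Statements on the series, on what has been measured and on what is new or still open speak of the compounds shown alone.

Measured so far in a functional assay on the whole organism (strain NMRI) with Mus musculus as the target, with a stated time of 30 min; on this read-out higher numbers stand for an effect only at larger amounts of compound and lower numbers for an effect already at smaller amounts:
compound 1 `CCC[C@@H](N)C(=O)NCc1ccccc1` gives 66 mg/kg
compound 2 `N[C@@H](C(=O)NCc1ccccc1)C1CCCCC1` gives 140 mg/kg
compound 3 `C#CCOCC(N)C(=O)NCc1ccccc1` gives 130 mg/kg

Compound 2 holds the highest of the three numbers in this assay. Against compound 3 the gap is within the scatter, so no order between these two is claimed. Against compound 1 the gap is beyond the scatter, and that pair is the one step between measured compounds that differ in a single place: a 2.1-fold higher number from compound 1 to compound 2 (0.33 log units; beyond the scatter).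

Compound 4 `CSCC[C@@H](N)C(=O)NCc1ccccc1` is the unmeasured member. Relative to compound 2 the change is 2-(methylsulfanyl)ethyl in place of cyclohexyl on a saturated chain carbon bound to an amine nitrogen and a carbonyl carbon. For the measured compounds named here, the one measured step that bears on this is a 2.1-fold higher number from compound 1 to compound 2 (0.33 log units; beyond the scatter), where the group on the same saturated chain carbon was also exchanged, an open chain for a ring, and the ring gave the higher number. Compound 4 carries an open chain again, so the expectation is a step back in the direction of compound 1, of about the same size. Going by the values given here, the sulfur in the chain has no counterpart among the measured compounds, so the range is kept wide. For compound 4 the expected step is a 2.0-fold lower number from compound 2 to compound 4 (0.30 log units; within the scatter). Compound 4 is estimated at 70 mg/kg, within 35 mg/kg to 140 mg/kg.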

Compound 4, minimum effective dose: 130 mg/kg
Compound 4: middle estimate off by 1.9-fold (0.27 log units), on the low side, and the stated range covers the measured number.
By their numbers in this assay, from the lowest: compounds 1, 3, 4 and 2 (each within the scatter of the next, the first and the last beyond it).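

In this assay the new comparison is a 1.1-fold lower number from compound 2 to compound 4 (0.03 log units; within the scatter), so at this place, a saturated chain carbon bound to an amine nitrogen and a carbonyl carbon, the open 2-(methylsulfanyl)ethyl chain and the cyclohexyl ring cannot be told apart. The second new comparison, a 2.0-fold higher number from compound 1 to compound 4 (0.29 log units; within the scatter), also stays within the scatter, so methylsulfanyl in place of methyl does not separate these two compounds either, and the gap between compound 1 and compound 2 can no longer be read as a simple contrast of open chain against ring: compound 4 carries an open chain and lies within the scatter of both. Nothing in hand offers an explanation for how these groups read at this position.

Still open, from the compounds shown here alone, is how a butyl chain or a 2-methoxyethyl group, with carbon or oxygen where compound 4 has sulfur, would read at this place, which would show whether the sulfur counts for anything on its own. Also open, going by these compounds, is whether a phenyl ring here would read with cyclohexyl or apart from it, and whether a carboxylic acid at the end of the chain would keep any effect in this assay at all.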